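Solubility notes: lactam-piperazine in place of methylpiperidine

This account rests on a few compounds, and the source may have more. Where it says the series, first, only, none or still open, it means among the compounds named here.

Measured so far in a physicochemical assay for solubility, read by HPLC, in phosphate buffer, measured as kinetic solubility, with a stated time of 1 h, at pH 7.4, tested at 250 uM; a lower number here means a less soluble compound, a higher number a more soluble compound:
compound 1 `CC(C)N1CCC(c2ccc3c(c2)oc(=O)n3C(=O)NCCCCc2ccccc2)CC1`: 50000 nM
compound 2 `CN1CCN(c2ccc3c(c2)oc(=O)n3C(=O)NCCCCc2ccccc2)CC1`: a limit only, < 1000 nM
compound 3 `CN1CCC(c2ccc3c(c2)oc(=O)n3C(=O)NCCCCc2ccccc2)CC1`: 120000 nM

Compound 3 stands highest of the two numbers shown; compound 1 is nearest, the step being a 2.4-fold higher number from compound 1 to compound 3 (0.38 log units; beyond the scatter). Compound 4 `CN1CCN(c2ccc3c(c2)oc(=O)n3C(=O)NCCCCc2ccccc2)C(=O)C1` is not yet measured. The change from compound 3 is 4-methyl-2-oxopiperazin-1-yl in place of 1-methylpiperidin-4-yl on an aromatic carbon. Among the measured compounds shown here, no measured step makes exactly this swap. For the measured compounds named here, the steps that bear on it are those between the ring-nitrogen-linked piperazine of compound 2 and the carbon-linked piperidines: an at least 120-fold higher number from compound 2 to compound 3 (2.07 log units; beyond the scatter) and an at least 50-fold lower number from compound 1 to compound 2 (1.69 log units; beyond the scatter), both large. For compound 2 the value is a limit (the limit of < 1000 nM in this assay, at which 1 of the 3 values shown sits). A large decrease is therefore expected for compound 4, estimated as a 20-fold lower number from compound 3 to compound 4 (1.30 log units; beyond the scatter). The estimate for compound 4 in this assay is 6000 nM, with a range from 700 nM to 50000 nM.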

Compound 4, solubility: 20000 nM
Estimate against measurement, compound 4: 3.3-fold (0.52 log units) below; measured number inside the range.
By their numbers in this assay, from the lowest: compound 4; then compound 1; then compound 3. At a limit, below all of these: compound 2.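

In this assay, with 4-methyl-2-oxopiperazin-1-yl on the aromatic carbon, the result is an at least 20-fold higher number from compound 2 to compound 4 (1.30 log units; beyond the scatter), so a piperazine-type ring attached through nitrogen at this position need not give a limit. The groups attached through carbon still give the higher numbers, with a 6.0-fold lower number from compound 3 to compound 4 (0.78 log units; beyond the scatter) and a 2.5-fold lower number from compound 1 to compound 4 (0.40 log units; beyond the scatter), both modest steps. The first reading rests on compound 2, whose value is a limit and not a number: the limit of < 1000 nM in this assay, at which 1 of the 4 values shown sits.

Still open, as far as these compounds go, is how a morpholine ring at this aromatic carbon would read, or an isopropyl in place of the methyl on the oxopiperazine nitrogen.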